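The compounds below may be only part of what the source reports. "The series", "measured", "known", "first", "only" and "open" are said of these compounds alone.

In a functional assay on SMMC-7721 cells (Homo sapiens) for cytotoxicity, read by MTT assay, with a stated time of 24 h (on this read-out lower numbers stand for stronger inhibition and higher numbers for weaker inhibition), compound 1 (`O=C1/C(=C/c2cccnc2)CN(S(=O)(=O)c2ccc([N+](=O)[O-])cc2)C/C1=C\c1ccccc1F`) returns > 20000 nM as a limit of the assay, not a number. In this assay compound 2 (`Cc1ccc(S(=O)(=O)N2C/C(=C\c3cccnc3)C(=O)/C(=C/c3ccccc3C(F)(F)F)C2)cc1`) gives 6700 nM and compound 3 (`O=C1/C(=C/c2cccnc2)CN(S(=O)(=O)c2ccc([N+](=O)[O-])cc2)C/C1=C\c1ccccc1C(F)(F)F`) gives 15900 nM as the higher of the two actual numbers.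

Compound 4 (`N#Cc1ccc(S(=O)(=O)N2C/C(=C\c3cccnc3)C(=O)/C(=C/c3ccccc3C(F)(F)F)C2)cc1`) carries cyano in place of nitro on an aromatic carbon and is otherwise unchanged. For the measured compounds named here, no measured step makes this exchange. The closest is nitro in place of methyl on an aromatic carbon, which gave a 2.4-fold higher number from compound 2 to compound 3 (0.38 log units; beyond the scatter) and counts as modest. Trifluoromethyl in place of fluoro gave an at least 1.2-fold lower number from compound 1 to compound 3 (0.09 log units; that floor lies within the scatter) and bears only weakly, as it concerns another group.

The modest size of a 2.4-fold higher number from compound 2 to compound 3 (0.38 log units; beyond the scatter) points to a small move at most. In this assay the expected result is a 1.4-fold lower number from compound 3 to compound 4 (0.16 log units; within the scatter) as a slight shift toward a lower number, with no expected change beyond the scatter. For compound 4 the estimate is 11000 nM with 5000 nM to 20000 nM as the expected range.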

Compound 4, half-maximal inhibitory concentration: 9650 nM
Beside the measured number, compound 4's estimate is 1.1-fold (0.06 log units) above it, within the range that was stated.
By their numbers in this assay, from the lowest: compounds 2, 4 and 3 (each within the scatter of the next, the first and the last beyond it). At a limit, above all of these: compound 1.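

In this assay cyano in place of nitro, para to a large group, gives a 1.6-fold lower number from compound 3 to compound 4 (0.22 log units; within the scatter) and so does not separate these two groups. Cyano in place of methyl at the same carbon gives a 1.4-fold higher number from compound 2 to compound 4 (0.16 log units; within the scatter) and does not separate those two groups either. For the compounds shown here, compound 4 thus stands within the scatter of both neighbours, and the only step beyond the scatter at this carbon remains a 2.4-fold higher number from compound 2 to compound 3 (0.38 log units; beyond the scatter) with cyano giving no clear rank between methyl and nitro.

Going by these compounds, whether an amine or a carboxylic acid at this carbon would move the number beyond the scatter stays open. The data shown give no cause for these small steps.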